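This account rests on a few compounds, and the source may have more. Where it says the series, first, only, none or still open, it means among the compounds named here.

Compound 1 `O=C(CCl)Nc1ccc(SCC(=O)Nc2ccc(Cl)cn2)cc1` is the reference point of this small series. In a functional assay on HeLa cells (Homo sapiens) for antiproliferative activity, read by MTT assay, with a stated time of 48 h (a lower number here means a stronger inhibitor, a higher number a weaker inhibitor), compound 1 gives 2500 nM, the lowest of the two plain numbers recorded. Its nearest neighbour is compound 2 `O=C(CCl)Nc1ccc(SCC(=O)Nc2cc(Cl)ccn2)cc1`, which in this assay gives 2800 nM; the step of a 1.1-fold higher number from compound 1 to compound 2 (0.05 log units; within the scatter) stays within the scatter. Compound 3 `O=C(CCl)Nc1ccc(SCC(=O)Nc2ccc(Cl)cc2)cc1` is different: in this assay compound 3 reaches only a limit, > 80000 nM, which is the limit of > 80000 nM in this assay, at which 1 of the 3 values shown sits. The steps of an at least 32-fold higher number from compound 1 to compound 3 (1.50 log units; beyond the scatter) and an at least 28-fold higher number from compound 2 to compound 3 (1.45 log units; beyond the scatter) are both large and beyond the scatter.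

The next compound, compound 4 `O=C(CCCCl)Nc1ccc(SCC(=O)Nc2ccc(Cl)cn2)cc1`, departs from compound 1 elsewhere: 2-chloroethyl in place of chloro on a saturated chain carbon bound to a carbonyl carbon. Among the measured compounds shown here, none of the measured steps touches this part of the molecule; every one of them exchanges the group on the amide-type nitrogen and leaves the chain bound to the carbonyl carbon untouched. The measured steps therefore give no direct guide to the size or direction of the step into compound 4, and the expectation rests on the change itself. For compound 4 in this assay a weaker outcome is expected, with a step of an 8.0-fold higher number from compound 1 to compound 4 (0.90 log units; beyond the scatter) from compound 1. The estimate for compound 4 is 20000 nM, within a range from 5000 nM to 80000 nM.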

Compound 4, half-maximal inhibitory concentration: > 80000 nM
Compound 4: a limit, no number; the forecaster's own chance of this, stated with the estimate: 30%; middle value at least 4.0-fold (0.60 log units) from the limit.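

Among the compounds shown here, until this result, every measured step had changed only the group on the amide-type nitrogen. Here that group is held constant, and the change from chloromethyl to 3-chloropropyl on the carbonyl gives an at least 32-fold higher number from compound 1 to compound 4 (1.50 log units; beyond the scatter). In this assay, from the compounds shown here alone, the value of compound 4 is a limit and not a number, so the step gives only the smallest size the change can have: the limit of > 80000 nM in this assay, at which 2 of the 4 values shown sit. The chain bound to the carbonyl carbon is therefore a second place, besides the group on the amide-type nitrogen, where a single change to compound 1 takes the read-out to that limit, and the true size of the step remains unknown.

The compounds shown leave open how a chain of intermediate length, such as 2-chloroethyl on the carbonyl carbon, would read, and whether compound 2 would respond to the same chain change as compound 1 does. They also leave open what an amine or a hydroxyl group in place of the chloro on the saturated chain carbon would give in this assay.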